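From 4-fluorobenzyl to 2,6-difluorobenzyl

The source may hold more compounds than are shown below. What is called first, only, known or untested is meant among the compounds shown, and "the series" means these compounds.

Compound 1 `O=[N+]([O-])c1ccc(CSc2nnc(-c3ccc4c(c3)OCCO4)n2-c2ccccc2)cc1`: 36200 nM
Compound 2 `Cc1ccccc1CSc1nnc(-c2ccc3c(c2)OCCO3)n1-c1ccccc1`: 36000 nM
Compound 3 `Fc1ccc(CSc2nnc(-c3ccc4c(c3)OCCO4)n2-c2ccccc2)cc1`: 46900 nM

In a functional assay on HeLa cells (Homo sapiens) for antiproliferative activity, read by MTT assay, with a stated time of 24 h (on this read-out lower numbers stand for stronger inhibition and higher numbers for weaker inhibition), compound 3 gives 46900 nM, which cannot be told apart from the other two measured compounds: a 1.3-fold higher number from compound 1 to compound 3 (0.11 log units; within the scatter) and a 1.3-fold higher number from compound 2 to compound 3 (0.11 log units; within the scatter). Compound 4 `Fc1cccc(F)c1CSc1nnc(-c2ccc3c(c2)OCCO3)n1-c1ccccc1` keeps the shared core and changes one group: 2,6-difluorophenyl in place of 4-fluorophenyl on a saturated chain carbon bound to a sulfur. The change is 2,6-difluorophenyl in place of 4-fluorophenyl, on a saturated chain carbon bound to a sulfur. Swaps of this same group gave a 1.0-fold lower number from compound 1 to compound 2 (0.00 log units; within the scatter) and a 1.3-fold higher number from compound 2 to compound 3 (0.11 log units; within the scatter), both within the scatter. Within the data shown here, no measured compound carries two fluoro groups, so this evidence is indirect. No step beyond the scatter is expected, and the estimate is a 1.2-fold lower number from compound 3 to compound 4 (0.07 log units; within the scatter). Compound 4 is expected at 40000 nM, within an estimated range of 20000 nM to 75000 nM.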

Compound 4, half-maximal inhibitory concentration: 35200 nM
Estimate against measurement, compound 4: 1.1-fold (0.06 log units) above; the range from low to high includes it.
By their numbers in this assay, from the lowest: compounds 4, 2, 1 and 3 (each within the scatter of the next).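

In this assay, 2,6-difluorophenyl on this saturated chain carbon bound to a sulfur gives only small steps: a 1.3-fold lower number from compound 3 to compound 4 (0.12 log units; within the scatter), a 1.0-fold lower number from compound 2 to compound 4 (0.01 log units; within the scatter) and a 1.0-fold lower number from compound 1 to compound 4 (0.01 log units; within the scatter). Adding a second fluoro group therefore extends the earlier picture, and all four compounds now lie within the scatter of one another. No measurement is available to explain this flat result. The compounds shown leave open whether any group here can move the number beyond the scatter. An amine, a carboxylic acid or a longer chain in place of the substituted phenyl ring would test this.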